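Methoxymethyl for Phenyl on a Bis-aziridinyl Quinone Side Chain

The source may hold more compounds than are shown below. What is called first, only, known or untested is meant among the compounds shown, and "the series" means these compounds.

Three compounds sharing one quinone core, each bearing two aziridine rings, have been measured in a functional assay on L1210 cells (Mus musculus), with a stated time of 1 days; a lower number here means a less potent compound, a higher number a more potent compound, by a factor of ten per unit of this negative logarithm. Compound 1 `CCCC1=C(N2CC2)C(=O)C(C(COC(N)=O)OC)=C(N2CC2)C1=O` gives 5.01, compound 2 `CC1=C(N2CC2)C(=O)C(Cc2ccccc2)=C(N2CC2)C1=O` gives 4.74, and compound 3 `CCOC(COC(N)=O)C1=C(N2CC2)C(=O)C(C)=C(N2CC2)C1=O` gives 5.53. Compound 2 stands within the scatter of compound 1 and sits beyond the scatter below compound 3, so only the gap to compound 3 can be read as a real difference.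

The step from compound 2 leads to compound 4 `COCCC1=C(N2CC2)C(=O)C(C)=C(N2CC2)C1=O`, which has not been measured in this assay. The change is methoxymethyl in place of phenyl on a saturated chain carbon bound to a double-bonded ring carbon. Compound 4 thus keeps the core and both aziridine rings and alters only the side chain on the saturated chain carbon bound to a double-bonded ring carbon.

Among the compounds with values here, no measured pair isolates this exact change, so any expectation rests on the three numbers alone. Compounds 1 and 3, whose side chains carry oxygen, both give higher numbers than compound 2, and compound 3 lies beyond the scatter above it. On that basis compound 4 is expected to give 5.2, with a range from 4.7 to 5.8. That estimate means a step of a number 0.46 log units higher from compound 2 to compound 4 (beyond the scatter), an expected gain of modest size rather than a large one, because compound 1 gives only 5.01.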

Compound 4, logarithm of the reciprocal of the active concentration, log(1/C): 5.19
Estimate against measurement, compound 4: 0.01 log units above; the measured number falls inside the stated range.
By their numbers in this assay, from the lowest: compounds 2, 1 and 4 (each within the scatter of the next, the first and the last beyond it); then compound 3.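

Within the data shown here, this is the first pair that differs in one place only, so the effect of the side chain can be read directly, free of the other differences that separate the earlier compounds. In this assay, methoxymethyl in place of phenyl on a saturated chain carbon bound to a double-bonded ring carbon gives a number 0.45 log units higher from compound 2 to compound 4 (beyond the scatter), which shows that the aromatic ring of the benzyl group is not needed at this position for the activity seen here and that the shorter, ring-free 2-methoxyethyl group, which carries one hydrogen-bond acceptor, is accepted in its place. Nothing shown here gives a measured reason for this gain.

The change removes the phenyl ring and brings in an oxygen at once, so the compounds shown leave open whether the gain follows the loss of the ring, the arrival of the oxygen, or both. An all-carbon chain such as butyl at this position would separate the two, and a hydroxyl or an amine at the end of the chain would show whether the ether oxygen can be replaced.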